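The compounds below may be only part of what the source reports. "The series", "measured", "known", "first", "only" and "open" are said of these compounds alone.

Working notes on the series. Among the compounds with values here, compound 1 `CC1CCN(c2c(S(=O)(=O)c3ccc(F)c(Cl)c3)cnc3cc(F)ccc23)CC1` in an assay on isolated protein for displacement of a labelled ligand from metabotropic glutamate receptor 5 (Homo sapiens), with a stated time of 60 min, tested at 1 uM (on this read-out lower numbers stand for less inhibition and higher numbers for more inhibition at the one concentration tested (going by the name of the read-out)), gives 94%, level with compound 2 `CC1CCN(c2c(S(=O)(=O)c3ccc(F)c(Cl)c3)cnc3cc(Cl)ccc23)CC1`, which gives 94% in this assay; the step of no change at the digits printed from compound 1 to compound 2 (within the scatter) is the only one-place step measured. Compound 3 `O=S(=O)(c1ccc(F)cc1)c1cnc2cc(Cl)ccc2c1N1CCC(CO)CC1` gives 75% in this assay, the furthest from compound 1 and beyond the scatter, but it differs from compound 1 in two places, so its gap cannot be assigned to either.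

Compound 4 `COc1ccc(S(=O)(=O)c2cnc3cc(F)ccc3c2N2CCC(C)CC2)cc1OC` differs from compound 1 by 3,4-dimethoxyphenyl in place of 3-chloro-4-fluorophenyl on a sulfonyl sulfur. Within the data shown here, no measured step touches the group on the sulfonyl sulfur, so nothing directly bears on this change. In this assay a moderate step down, a number 14 percentage points lower from compound 1 to compound 4 (beyond the scatter), is expected for compound 4. Compound 4 is estimated at 80%, within 55% to 95%.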

Compound 4, a percentage reported as inhibition, at one concentration (the size of the read-out at that concentration, not a potency): 83%
For compound 4 the middle estimate is 3 percentage points below the measured one, within the range that was stated.
By their numbers in this assay, from the lowest: compounds 3 and 4 (each within the scatter of the next); then compounds 1 and 2 (each within the scatter of the next).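

In this assay the group on the sulfonyl sulfur now has a step of its own: 3,4-dimethoxyphenyl in place of 3-chloro-4-fluorophenyl gives a number 11 percentage points lower from compound 1 to compound 4 (beyond the scatter) as the result. Unlike the one-place step from chloro to fluoro on the core, this change lies beyond the scatter, so the readout responds to this position, although compound 4 still gives 83% at the one concentration tested. No evidence on hand accounts for this step.

Open, on these data alone, is whether either methoxy group alone carries the step, and how an amine or a carboxylic acid on that phenyl ring would read.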